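The source may report more compounds than this note shows. Statements on the series, on what has been measured and on what is new or still open speak of the compounds shown alone.

Measured compounds in the series:
compound 1 `CC1=C(C(=O)OCC(C)C)C(c2cccs2)NC(=O)N1` — 11%
compound 2 `CC1=C(C(=O)NC(C)C)C(c2cccs2)NC(=O)N1` — 1%

In an assay on membranes from HeLa cells for displacement of a labelled ligand from adenosine receptor A3 (Homo sapiens), read by scintillation counting, with a stated time of 180 min, tested at 1 uM (a lower number here means less inhibition, a higher number more inhibition at the concentration tested (going by the name of the read-out)), compound 1 gives 11% and compound 2 gives 1%; the two numbers sit within the scatter of each other, so neither can be set above the other. Among the compounds with values here, the one step recorded so far, a number 10 percentage points lower from compound 1 to compound 2 (within the scatter), concerns the same carbonyl carbon and falls within the scatter.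

Compound 3 `CCN(CC)C(=O)C1=C(C)NC(=O)NC1c1cccs1` differs from compound 2 in one place: diethylamino in place of isopropylamino on a carbonyl carbon. Within the data shown here, the only step that bears on it is a number 10 percentage points lower from compound 1 to compound 2 (within the scatter), which exchanged one group on that carbonyl carbon for another without moving the number beyond the scatter. Among the measured compounds shown here, no step is available in which a group without a hydrogen-bond donor enters at this position, so the expectation rests on the two numbers alone. A step of about a number 4 percentage points higher from compound 2 to compound 3 (within the scatter) is expected, that is none beyond the scatter. For compound 3 the estimate is 5%, with a range from -8% to 20%.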

Compound 3, a percentage reported as inhibition, at one concentration (the size of the read-out at that concentration, not a potency): 31%
For compound 3 the middle estimate is 26 percentage points below the measured one, and the stated range ends below it.
By their numbers in this assay, from the lowest: compounds 2 and 1 (each within the scatter of the next); then compound 3.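

In this assay, the group on this carbonyl carbon can move the number beyond the scatter: a number 30 percentage points higher from compound 2 to compound 3 (beyond the scatter) for diethylamino in place of isopropylamino, and a number 20 percentage points higher from compound 1 to compound 3 (beyond the scatter) for diethylamino in place of isobutoxy. Within the data shown here, the earlier exchange at this carbonyl carbon stayed within the scatter, so diethylamino is the first group here set apart from the others. Going from isopropylamino to diethylamino removes the amide hydrogen, but compound 1, with isobutoxy and no amide hydrogen either, stays within the scatter of compound 2, so the absence of that hydrogen does not track the number on its own, and no measurement on hand explains the step.

Still open, on these data alone, is whether the higher number is particular to diethylamino or extends to dimethylamino, a piperidine amide or longer chains on the nitrogen. All three numbers come from a single concentration, so none of them gives a potency.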